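Cytotoxicity notes: acetamido series, removal of diethylamino

The source may report more compounds than this note shows. Statements on the series, on what has been measured and on what is new or still open speak of the compounds shown alone.

Measured so far in an ADME assay on Vero cells (Chlorocebus sabaeus) for cytotoxicity; a higher number here means that more compound is tolerated, a lower number that less compound is tolerated:
compound 1 `CC(=O)Nc1ccc(-c2nc3cc(C(F)(F)F)ccc3n2C)cc1`: > 100000 nM
compound 2 `O=C(O)CCC(=O)Nc1ccc(-c2nc3cc(C(F)(F)F)ccc3[nH]2)cc1`: > 100000 nM
compound 3 `CCN(CC)CC(=O)Nc1ccc(-c2nc3cc(C(F)(F)F)ccc3[nH]2)cc1`: 24000 nM

The value of compound 1 is a limit of the assay and not a number. The value of compound 2 is likewise a limit. Among the measured compounds shown here, compound 3 is therefore the only compound with an actual number in this assay; the two other values sit at a limit, as the limit of > 100000 nM in this assay, at which 2 of the 3 values shown sit, notes.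

For the measured compounds named here, the one step between measured compounds, an at least 4.1-fold lower number from compound 2 to compound 3 (0.61 log units; beyond the scatter), puts diethylamino in place of carboxymethyl and moves the read-out from a limit to a number; its size is bounded only from one side because of the limit of > 100000 nM in this assay, at which 2 of the 3 values shown sit.

Compound 4 `CC(=O)Nc1ccc(-c2nc3cc(C(F)(F)F)ccc3[nH]2)cc1` is not yet measured. It differs from compound 3 as follows: hydrogen in place of diethylamino on a saturated chain carbon bound to a carbonyl carbon. The change removes the very group whose arrival marked the step from compound 2 to compound 3, so the expectation is a move back in the opposite direction, toward a higher number. Compound 1, which also carries acetamido, shows only a limit in this assay.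

For compound 4 the expected step is a 4.2-fold higher number from compound 3 to compound 4 (0.62 log units; beyond the scatter), most likely ending again at a limit. The estimate for compound 4 is 100000 nM, with a range from 40000 nM to 250000 nM.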

Compound 4, half-maximal cytotoxic concentration: 50000 nM
Compound 4: middle estimate off by 2.0-fold (0.30 log units), on the high side; the range from low to high includes it.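

In this assay, hydrogen in place of diethylamino on a saturated chain carbon bound to a carbonyl carbon gives a 2.1-fold higher number from compound 3 to compound 4 (0.32 log units; beyond the scatter), a modest step with a number at both ends. Removing diethylamino therefore moves the read-out in the direction expected, but compound 4 still gives a number and does not return to the limit, so the absence of diethylamino alone does not carry the acetamido compound to that limit in this series. The two other steps, an at least 2.0-fold lower number from compound 2 to compound 4 (0.30 log units; that floor lies within the scatter) and an at least 2.0-fold lower number from compound 1 to compound 4 (0.30 log units; that floor lies within the scatter), cannot be read, because each starts from a limit, so their true size stays unknown: the limit of > 100000 nM in this assay, at which 2 of the 4 values shown sit.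

The compounds shown leave open how a primary amine, a morpholine or a longer chain on the same saturated chain carbon would read, and therefore whether the lower number of compound 3 belongs to diethylamino specifically or to amines at this carbon more generally. They also leave open how far methyl on the aromatic nitrogen moves the number, as compound 1 stands at a limit.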